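Acetyl for nitro on compound 2

This account rests on a few compounds, and the source may have more. Where it says the series, first, only, none or still open, it means among the compounds named here.

Compound 2 `O=C(/C=C/C(=O)N1C/C(=C\c2ccccc2)C(=O)/C(=C/c2ccccc2)C1)Nc1ccc([N+](=O)[O-])cc1` gives the highest number of the three measured compounds in a functional assay on L1210 cells (Mus musculus) for cytotoxicity (on this read-out higher numbers stand for weaker inhibition and lower numbers for stronger inhibition), at 40000 nM. Compound 1 `COc1ccc(NC(=O)/C=C/C(=O)N2C/C(=C\c3ccc([N+](=O)[O-])cc3)C(=O)/C(=C/c3ccc([N+](=O)[O-])cc3)C2)cc1` gives 2900 nM and compound 3 `CC(=O)c1ccc(NC(=O)/C=C/C(=O)N2C/C(=C\c3ccc([N+](=O)[O-])cc3)C(=O)/C(=C/c3ccc([N+](=O)[O-])cc3)C2)cc1` gives 1400 nM in this assay; both carry nitro-bearing arms on the shared core, so neither pair with compound 2 is a single-point change. Compound 4 `CC(=O)c1ccc(NC(=O)/C=C/C(=O)N2C/C(=C\c3ccccc3)C(=O)/C(=C/c3ccccc3)C2)cc1` differs from compound 2 by acetyl in place of nitro on an aromatic carbon. Among the compounds with values here, no measured step exchanges nitro for acetyl. Within the data shown here, the one step that also brings in acetyl, a 2.1-fold lower number from compound 1 to compound 3 (0.32 log units; beyond the scatter), starts from methoxy and lowers the number modestly. On that thin basis a modest lowering is expected for compound 4, a 2.0-fold lower number from compound 2 to compound 4 (0.30 log units; within the scatter). Compound 4 is therefore estimated at 20000 nM, with a range of 7000 nM to 60000 nM.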

Compound 4, half-maximal inhibitory concentration: 5500 nM
For compound 4 the middle estimate is 3.6-fold (0.56 log units) above the measured one; measured number outside the range, below it.
By their numbers in this assay, from the lowest: compound 3; then compounds 1 and 4 (each within the scatter of the next); then compound 2.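

On the aromatic carbon para to a large group, a 7.3-fold lower number from compound 2 to compound 4 (0.86 log units; beyond the scatter) shows that acetyl in place of nitro moves the number beyond the scatter when the arms of the shared core carry no nitro. Together with a 2.1-fold lower number from compound 1 to compound 3 (0.32 log units; beyond the scatter), acetyl now lowers the number against two different groups, methoxy and nitro, on two different sets of arms. No data at hand explain the change.

Going by these compounds, whether an amine or a carboxylic acid at this position would lower the number further remains open. So does how a methoxy analogue of compound 4 would compare.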